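Swapping Trifluoromethyl for Hydroxy in Compound 4

A few compounds are considered here, and "the series" means these few. Any claim that something is new, unique, unknown or untested is made for them only; others in the source may bear on it.

Compound 1 `O=C(Nc1ccccc1C(F)(F)F)C1CCc2ccccc2N1C(=O)c1cccc(Cl)c1` is the reference point of this small set. In a functional assay on MDA-MB-231 cells (Homo sapiens) for cytotoxicity, read by sulforhodamine B assay, with a stated time of 72 h (a lower number here means a stronger inhibitor of growth, a higher number a weaker inhibitor of growth), compound 1 gives 288 nM, the lowest of the two numbers measured here. Compound 3 `O=C(Nc1ccccc1C(F)(F)F)C1CCc2ccccc2N1C(=O)c1ccccc1Cl`, which carries 2-chlorophenyl in place of 3-chlorophenyl on the carbonyl carbon, gives 2530 nM in this assay, and the step of an 8.8-fold higher number from compound 1 to compound 3 (0.94 log units; beyond the scatter) lies beyond the scatter. Compound 2 `CC(=O)N1c2ccccc2CCC1C(=O)Nc1ccccc1C(F)(F)F`, with methyl on that carbonyl carbon, reaches only a limit of this assay, reported as > 80000 nM. The step of an at least 270-fold higher number from compound 1 to compound 2 (2.44 log units; beyond the scatter) is large, and an at least 31-fold lower number from compound 2 to compound 3 (1.49 log units; beyond the scatter) runs the other way.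

Compound 4 `O=C(Nc1ccccc1O)C1CCc2ccccc2N1C(=O)c1cccc(Cl)c1` differs from compound 1 elsewhere: hydroxy in place of trifluoromethyl on an aromatic carbon. Among the measured compounds shown here, none of the measured steps touches this part of the molecule; all three alter the group on the carbonyl carbon. They therefore give no direct guide to the size or direction of the step from compound 1 to compound 4, and the expectation rests on the structural change alone, with wide uncertainty. A moderate weakening is expected, estimated as a 5.2-fold higher number from compound 1 to compound 4 (0.72 log units; beyond the scatter). Compound 4 is estimated at 1500 nM, within a range from 200 nM to 15000 nM.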

Compound 4, concentration for 50% growth inhibition: 10600 nM
For compound 4 the middle estimate is 7.1-fold (0.85 log units) below the measured one, and the stated range covers the measured number.
By their numbers in this assay, from the lowest: compound 1; then compound 3; then compound 4. At a limit, above all of these: compound 2.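

In this assay, among the compounds shown here, the change from 2-(trifluoromethyl)phenyl to 2-hydroxyphenyl gives a 37-fold higher number from compound 1 to compound 4 (1.57 log units; beyond the scatter) and so shows that growth inhibition depends on this aromatic ring as well as on the group on the carbonyl carbon, the only part altered by the earlier steps. Moving the chlorine around its ring gave an 8.8-fold higher number from compound 1 to compound 3 (0.94 log units; beyond the scatter) as a modest step, whereas this exchange at a different part of the molecule is a large one, so this aromatic carbon is far from indifferent to what it carries. No measurement shown bears on why this exchange weakens growth inhibition.

On these data alone, with only one replacement at this carbon, it stays open whether the loss comes from removing trifluoromethyl or from introducing hydroxy, and whether a methoxy group, a chlorine atom or an amine would keep the number nearer that of compound 1. As far as these compounds go, it is also open whether the same exchange would have a similar effect when the carbonyl carbon carries 2-chlorophenyl, as in compound 3, rather than 3-chlorophenyl.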